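Sulfonamide aryl variation in the antiproliferative series

A few compounds are considered here, and "the series" means these few. Any claim that something is new, unique, unknown or untested is made for them only; others in the source may bear on it.

Compound 2 `Cc1ccc(S(=O)(=O)NCc2cn(C[C@H](O)[C@H]3OC(=O)C(OCc4ccccc4)=C3OCc3ccccc3)nn2)cc1` gives the lowest of the two numbers in a functional assay on HeLa cells (Homo sapiens) for antiproliferative activity, read by MTT assay, with a stated time of 72 h; a lower number here means a stronger inhibitor, a higher number a weaker inhibitor; compound 2 gives 14400 nM. Among the compounds with values here, compound 1 `O=C1O[C@H]([C@@H](O)Cn2cc(CCCCl)nn2)C(OCc2ccccc2)=C1OCc1ccccc1` is its nearest neighbour and in this assay compound 1 gives 36700 nM; the only measured step, a 2.5-fold lower number from compound 1 to compound 2 (0.41 log units; beyond the scatter), is modest and lies beyond the scatter.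

Compound 3 `O=C1O[C@H]([C@@H](O)Cn2cc(CNS(=O)(=O)c3ccc(Cl)cc3F)nn2)C(OCc2ccccc2)=C1OCc1ccccc1` differs from compound 2 in one place: 4-chloro-2-fluorophenyl in place of 4-methylphenyl on a sulfonyl sulfur. Within the data shown here, no measured step touches the aryl on the sulfonyl sulfur; the single step from compound 1 to compound 2 concerns the substituent on the saturated chain carbon and so does not directly bear on this change. Among the measured compounds shown here, with only that step for scale, and it being modest, no step beyond the scatter is expected in this assay for the exchange of one aryl on the sulfonyl sulfur for another. Compound 3 is therefore expected to give about 12000 nM, with a plausible range from 5000 nM to 35000 nM; the expected step is a 1.2-fold lower number from compound 2 to compound 3 (0.08 log units; within the scatter).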

Compound 3, half-maximal inhibitory concentration: 20700 nM
Compound 3: the middle estimate sits 1.7-fold (0.24 log units) below what was measured; the measured number falls inside the stated range.
By their numbers in this assay, from the lowest: compounds 2, 3 and 1 (each within the scatter of the next, the first and the last beyond it).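

On the sulfonyl sulfur, 4-chloro-2-fluorophenyl and 4-methylphenyl are not separated in this assay: the exchange gives a 1.4-fold higher number from compound 2 to compound 3 (0.16 log units; within the scatter), so this first reading at the position shows no response to replacing the methyl-bearing aryl with the chlorine- and fluorine-bearing one. The advantage of the sulfonylamino series over the 2-chloroethyl group also depends on the aryl, at least in these compounds: a 2.5-fold lower number from compound 1 to compound 2 (0.41 log units; beyond the scatter) lies beyond the scatter with 4-methylphenyl, whereas a 1.8-fold lower number from compound 1 to compound 3 (0.25 log units; within the scatter) stays within it with 4-chloro-2-fluorophenyl. No supporting measurement is available to account for any of these steps.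

Within the data shown here, with only two substituted phenyl groups on the sulfonyl sulfur, it remains open whether a clearly different group there, such as a pyridine ring, a naphthyl group or a simple methyl, would move the number beyond the scatter. From the compounds shown here alone, it is also open whether the response belongs to the sulfonyl linkage itself, which a carboxamide in its place on the same chain carbon would test.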